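A few compounds are considered here, and "the series" means these few. Any claim that something is new, unique, unknown or untested is made for them only; others in the source may bear on it.

Compound 2 `COc1cc(-c2nn(-c3cccc(NC(=O)Nc4cccc(C(F)(F)F)c4)c3)cc2-c2ccncc2)ccc1Cl` and compound 1 `COc1cc(-c2nn(-c3cccc(NC(=O)Nc4ccc(Cl)c(Cl)c4)c3)cc2-c2ccncc2)ccc1Cl` share one core and differ only in the ring carried on an amide-type nitrogen. In a functional assay on UACC-62 cells (Homo sapiens) for inhibition, read by sulforhodamine B assay, with a stated time of 48 h (on this read-out higher numbers stand for weaker inhibition of growth and lower numbers for stronger inhibition of growth), compound 1 gives 1860 nM, and in this assay compound 2 gives 1590 nM. For the measured compounds named here, the single measured step, a 1.2-fold lower number from compound 1 to compound 2 (0.07 log units; within the scatter), leaves the two values within the scatter of each other, so compound 2 stands at the low end of the pair without being separable from compound 1 on these numbers.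

Compound 3 `COc1cc(-c2nn(-c3cccc(NC(=O)c4ccc(Cl)c(C(F)(F)F)c4)c3)cc2-c2ccncc2)ccc1Cl` differs from compound 2 in 4-chloro-3-(trifluoromethyl)phenyl in place of (3-(trifluoromethyl)phenyl)amino on a carbonyl carbon. Going by the values given here, no measured step bears on a change of this kind: the step between compound 1 and compound 2 exchanged one ring for another on the nitrogen and kept the carbonyl's neighbours unchanged, whereas here a nitrogen leaves the carbonyl and a ring takes its place. That measured step was itself within the scatter and offers no direction. The expected step is therefore a 1.3-fold higher number from compound 2 to compound 3 (0.10 log units; within the scatter), with no shift beyond the scatter foreseen. For compound 3 in this assay the estimate is 2000 nM, with a range from 700 nM to 6000 nM.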

Compound 3, concentration for total growth inhibition: > 32500 nM
Compound 3 ended at the assay's limit; the forecaster's own chance of this, stated with the estimate: 5%; middle value at least 16-fold (1.21 log units) away from the limit.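

On the carbonyl carbon, 4-chloro-3-(trifluoromethyl)phenyl in place of (3-(trifluoromethyl)phenyl)amino gives, in this assay, an at least 20-fold higher number from compound 2 to compound 3 (1.31 log units; beyond the scatter), so this place on the carbonyl carbon responds strongly where the earlier exchange of one ring for another on the amide-type nitrogen stayed within the scatter. The same holds against the (3,4-dichlorophenyl)amino group, with an at least 17-fold higher number from compound 1 to compound 3 (1.24 log units; beyond the scatter), so the result does not hang on one particular partner. The value of compound 3 is a limit of the assay and not a number, so the true size of both steps stays unknown: the limit of > 32500 nM in this assay, at which 1 of the 3 values shown sits.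

The change removes the amino nitrogen, with its hydrogen-bond donor, and brings in a chlorine in the same step, and these compounds cannot tell which of the two matters, or whether both do. Also open, from the compounds shown here alone, is how a methylene or a methylamino group would fare in place of the amino nitrogen on the carbonyl carbon, and whether the 4-chloro-3-(trifluoromethyl)phenyl ring would be tolerated with the amino nitrogen kept.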